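The source may hold more compounds than are shown below. What is called first, only, known or untested is meant among the compounds shown, and "the series" means these compounds.

Compound 1, `Cc1cc(=O)n(-c2cccc(F)c2)nc1C(=O)Nc1ccc(Oc2ncnc3c2ccn3C)cc1`, in a functional assay on HepG2 cells (Homo sapiens) for cytotoxicity, read by MTT assay, with a stated time of 72 h (a higher number here means a weaker inhibitor, a lower number a stronger inhibitor), gives > 60000 nM, which is a limit of the assay and not a number.
Compound 2, `Cc1cc(=O)n(-c2ccccc2OC(F)(F)F)nc1C(=O)Nc1ccc(Oc2ncnc3c2ccn3C)c(F)c1`, gives > 60000 nM, again a limit of the assay.
Compound 3, `Cc1cc(=O)n(-c2cccc(F)c2)nc1C(=O)Nc1ccc(Oc2ncnc3c2ccn3C)c(F)c1`, gives > 60000 nM, also a limit of the assay.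

Compound 3 therefore stands at the limit, and so do both compounds that differ from it in one place; the three values together sit at the limit of > 60000 nM in this assay, at which 3 of the 3 values shown sit. The step that the two limits leave unreadable from compound 1 to compound 3 and the step that the two limits leave unreadable from compound 2 to compound 3 are consequently both unreadable.

The move to compound 4, `Cc1cc(=O)n(-c2ccccc2C(F)(F)F)nc1C(=O)Nc1ccc(Oc2ncnc3c2ccn3C)c(F)c1`, is 2-(trifluoromethyl)phenyl in place of 3-fluorophenyl on an aromatic nitrogen. Among the measured compounds shown here, the only measured step that touches the same aromatic nitrogen is the one from compound 2 to compound 3, and it gives no readable size. Given that compound 3 sits at > 60000 nM, the step to compound 4 is expected to be no more than a change of one limit into another, a step that the limit leaves unreadable from compound 3 to compound 4. Compound 4 is therefore estimated at 80000 nM, between 25000 nM and 300000 nM, most probably reported again only as a limit.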

Compound 4, half-maximal inhibitory concentration: > 60000 nM
Compound 4 gave a limit, no number; the forecaster's own chance of this, stated with the estimate: 85%; the middle value does not contradict the limit.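

Compound 4 gives > 60000 nM as a limit of the assay and not a number, so its steps from compound 3 and from compound 2 cannot be read: the limit of > 60000 nM in this assay, at which 4 of the 4 values shown sit.

In this assay the compounds shown leave open how large any of these steps is, and whether any change on the aromatic nitrogen gives a readable value.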